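Trimming an amine side chain to isopropyl

The compounds below may be only part of what the source reports. "The series", "measured", "known", "first", "only" and "open" are said of these compounds alone.

Of the compounds shown here, three have been measured in a functional assay on DLD-1 cells (Homo sapiens) for inhibition, read by MTT assay, with a stated time of 72 h; a lower number here means a stronger inhibitor, a higher number a weaker inhibitor. There, compound 1 `COc1cc(Oc2cccc(Nc3ccccc3)c2)cc(OC)c1CNCc1ccccc1` gives 5220 nM, and compound 2 `COc1cc(Oc2cccc(Nc3ccccc3)c2)cc(OC)c1CNCCNC(C)=O` gives 6010 nM. Compound 3 `COc1ccc([C@@H](C)NCc2c(OC)cc(Oc3cccc(Nc4ccccc4)c3)c(OC)c2OC)cc1` gives 3500 nM, and its structure differs from both others in several places. The value of compound 2 lies within the usual scatter of both others, so these numbers do not separate it from either neighbour.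

The next compound, compound 4 `COc1cc(Oc2cccc(Nc3ccccc3)c2)cc(OC)c1CNC(C)C`, has not yet been measured. It carries isopropyl in place of 2-acetamidoethyl on an amine nitrogen.

Within the data shown here, only one measured step changes a single place, and it touches the same side chain: a 1.2-fold higher number from compound 1 to compound 2 (0.06 log units; within the scatter). In that step, acetamidomethyl stands in place of phenyl on a saturated chain carbon bound to an amine nitrogen. Among the measured compounds shown here, no measured compound yet shows what isopropyl itself does, so this is thin evidence. Still, the side chains of compound 1 and compound 2 are quite unlike, and that step stayed within the scatter. The same outcome is the best expectation here, with no clear direction.

The expected change is a 1.2-fold lower number from compound 2 to compound 4 (0.08 log units; within the scatter), which would not go beyond the scatter. Compound 4 is estimated at 5000 nM, with an expected range from 2300 nM to 11000 nM.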

Compound 4, half-maximal inhibitory concentration: > 20000 nM
Compound 4: a limit, no number; the forecaster's own chance of this, stated with the estimate: 5%; at least 4.0-fold (0.60 log units) between middle value and limit.
By their numbers in this assay, from the lowest: compounds 3, 1 and 2 (each within the scatter of the next). At a limit, above all of these: compound 4.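

In this assay, compound 4 gives a limit and not a number: the limit of > 20000 nM in this assay, at which 1 of the 4 values shown sits.

Among these compounds, this shows that the group on the amine nitrogen can matter here, which the earlier compounds gave no sign of: benzyl and 2-acetamidoethyl could not be told apart in a 1.2-fold higher number from compound 1 to compound 2 (0.06 log units; within the scatter), so that position might have seemed to accept very different groups equally well. Isopropyl breaks that picture, with an at least 3.3-fold higher number from compound 2 to compound 4 (0.52 log units; beyond the scatter) and an at least 3.8-fold higher number from compound 1 to compound 4 (0.58 log units; beyond the scatter), both beyond the scatter, and since these steps end at a limit, their true size could be larger still.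

What the compounds shown leave open is which feature of the side chain counts, since the step from 2-acetamidoethyl to isopropyl removes the amide and shortens the group at the same time, and benzyl, which has no amide, sits within the scatter of 2-acetamidoethyl. A plain longer chain such as n-butyl, or a ring such as cyclohexyl, on the same amine nitrogen would help show whether the loss follows the size of the group or the particular shape of isopropyl.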